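The source may report more compounds than this note shows. Statements on the series, on what has been measured and on what is new or still open speak of the compounds shown alone.

- compound 1 (`Fc1ccccc1CSc1nnc(-c2cnccn2)s1`): 32700 nM
- compound 2 (`Clc1ccc(CSc2nnc(-c3cnccn3)s2)cc1`): 18900 nM
- compound 3 (`Clc1cccc(CSc2nnc(-c3cnccn3)n2-c2ccccc2)c1`): 13500 nM

These three numbers come from a functional assay on HeLa cells (Homo sapiens) for antiproliferative activity, read by MTT assay, with a stated time of 48 h; a higher number here means a weaker inhibitor, a lower number a stronger inhibitor. Compound 3 (13500 nM) cannot be told apart from compound 2 (18900 nM), since the two values lie within the normal scatter of repeated measurements. Its number is lower than that of compound 1 (32700 nM), and that gap is beyond the scatter, so compound 3 is the stronger inhibitor of that pair.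

The next compound to be tested is compound 4 (`Brc1ccc(CSc2nnc(-c3cnccn3)n2-c2ccccc2)cc1`). Its difference from compound 3 (4-bromophenyl in place of 3-chlorophenyl on a saturated chain carbon bound to a sulfur) puts 4-bromophenyl in place of 3-chlorophenyl on a saturated chain carbon bound to a sulfur. Going by the values given here, no two measured compounds differ in one place only, so no direct comparison can guide a prediction for this change. The measured values do stay fairly close, running from compound 3 (13500 nM) to compound 1 (32700 nM). In this assay, no change beyond the scatter is therefore expected, and no clear direction either: the estimated step (a 1.1-fold lower number from compound 3 to compound 4 (0.05 log units; within the scatter)) is small. For compound 4 the estimated value is 12000 nM (expected range 5000 nM to 28000 nM).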

Compound 4, half-maximal inhibitory concentration: 8630 nM
Estimate against measurement, compound 4: 1.4-fold (0.14 log units) above; measured number inside the range.
By their numbers in this assay, from the lowest: compounds 4, 3, 2 and 1 (each within the scatter of the next, the first and the last beyond it).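

In this assay, going by these compounds alone, putting 4-bromophenyl in place of 3-chlorophenyl on a saturated chain carbon bound to a sulfur gives a 1.6-fold lower number from compound 3 to compound 4 (0.19 log units; within the scatter), the first direct comparison in this set of two compounds that differ in one place only. At this position, then, one halogen-bearing phenyl group can replace the other without a change that can be told from the normal scatter, although the halogen and its location on the ring both differ, and this single pair does not separate those two differences. The data offered here contain no measurement that could explain this outcome.

Going by these compounds, both groups compared are halogen-bearing phenyl rings, so it remains open how this position would respond to something quite different, such as an amine or a carboxylic acid on that ring, or a longer chain bound to the sulfur. Compounds 1 and 2 differ from compounds 3 and 4 in more than one place, so the contribution of the remaining parts of the core also stays unresolved.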